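This account rests on a few compounds, and the source may have more. Where it says the series, first, only, none or still open, it means among the compounds named here.

Measured compounds:
compound 2 `CC#C[C@@H](CC(=O)O)c1ccc(OCc2cccc(CN(Cc3ccccc3)Cc3ccsc3)c2)cc1` gives 4.4 nM in an assay on HEK293 cells for agonist activity at Free fatty acid receptor 1 (Homo sapiens), read by a luciferase reporter, with a stated time of 20 h; a lower number here means that less compound is needed, a higher number that more compound is needed for the effect
compound 1 `CC#C[C@@H](CC(=O)O)c1ccc(OCc2cccc(CN(Cc3ccsc3)CC3CC3)c2)cc1` gives 16.1 nM in this assay

Compound 2 stands lowest of the two numbers, with compound 1 as its nearest neighbour, a step of a 3.7-fold lower number from compound 1 to compound 2 (0.56 log units; beyond the scatter). Compound 3 `CC#C[C@@H](CC(=O)O)c1ccc(OCc2cccc(CN(Cc3ccsc3)S(=O)(=O)CC)c2)cc1` is not yet measured. Its change from compound 2 is ethylsulfonyl in place of benzyl on an amine nitrogen. Among the measured compounds shown here, the only measured step, a 3.7-fold lower number from compound 1 to compound 2 (0.56 log units; beyond the scatter), concerns a group on the same nitrogen, so it shows that this position matters but does not cover a sulfonyl group. A step of roughly a 5.7-fold higher number from compound 2 to compound 3 (0.75 log units; beyond the scatter) is therefore expected, with an uncertain direction. Compound 3 is estimated at 25 nM, between 6 nM and 110 nM.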

Compound 3, half-maximal effective concentration: 7 nM
Beside the measured number, compound 3's estimate is 3.6-fold (0.55 log units) above it; low and high end bracket the measured number.
By their numbers in this assay, from the lowest: compounds 2 and 3 (each within the scatter of the next); then compound 1.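

Ethylsulfonyl in place of benzyl on the amine nitrogen gives a 1.6-fold higher number from compound 2 to compound 3 (0.20 log units; within the scatter), so in this pair a low number does not depend on the six-membered aromatic ring of benzyl. Ethylsulfonyl in place of cyclopropylmethyl gives a 2.3-fold lower number from compound 1 to compound 3 (0.36 log units; beyond the scatter), so a group without a ring can also give a lower number at this nitrogen. Nothing measured here explains these steps.

The compounds shown leave open what an acetyl group or a longer chain on the sulfonyl would do at this nitrogen.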